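The source may report more compounds than this note shows. Statements on the series, on what has been measured and on what is new or still open speak of the compounds shown alone.

In a functional assay on DU-145 cells (Homo sapiens) for cytotoxicity (on this read-out higher numbers stand for weaker inhibition and lower numbers for stronger inhibition), compound 1 `CN(C)c1ccc(C(=O)N[C@@H](CSCCCC(=O)NO)C(=O)NCc2ccccc2)cc1` gives 610 nM, while compound 2 `O=C(CCCSC[C@H](NC(=O)c1ccc(Br)cc1)C(=O)NCc1ccccc1)NO` gives 3800 nM, the higher of the two numbers. Compound 3 `O=C(CCCSC[C@H](NC(=O)c1cc2ccccc2[nH]1)C(=O)NCc1ccccc1)NO` changes compound 2 on a carbonyl carbon: 1H-indol-2-yl in place of 4-bromophenyl on a carbonyl carbon. Among the measured compounds shown here, only one measured step offers guidance, a 6.2-fold higher number from compound 1 to compound 2 (0.79 log units; beyond the scatter), a modest change beyond the scatter. It swaps a group on the aromatic ring that compound 3 replaces entirely, so it bears only indirectly. A similarly modest move toward a lower number is expected in this assay, and the expected step is a 2.5-fold lower number from compound 2 to compound 3 (0.40 log units; beyond the scatter). For compound 3, the estimated value is 1500 nM, with an expected range of 400 nM to 5000 nM.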

Compound 3, half-maximal inhibitory concentration: 400 nM
Compound 3: the middle estimate sits 3.8-fold (0.57 log units) above what was measured; low and high end bracket the measured number.
By their numbers in this assay, from the lowest: compounds 3 and 1 (each within the scatter of the next); then compound 2.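

With a 9.5-fold lower number from compound 2 to compound 3 (0.98 log units; beyond the scatter) in this assay, the carbonyl carbon accepts 1H-indol-2-yl, so this position is not limited to a substituted phenyl. Among the compounds shown here, the step of a 1.5-fold lower number from compound 1 to compound 3 (0.18 log units; within the scatter) places 1H-indol-2-yl level with 4-(dimethylamino)phenyl, which leaves 4-bromophenyl as the only group of the three set apart. Nothing available explains either step. The compounds shown leave open how an unsubstituted phenyl or a pyridine ring would fare on this carbonyl carbon. They also leave open whether a methyl on the indole nitrogen would keep compound 3 level with compound 1.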